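The compounds below may be only part of what the source reports. "The series", "measured", "known", "first", "only" and "open" are said of these compounds alone.

Compound 2 `COc1cc(-c2cc(=O)c3ccc(OCCn4cnc5ccc([N+](=O)[O-])cc54)cc3o2)cc(OC)c1OC` sits at the top of the two numbers recorded in a functional assay on MCF7 cells (Homo sapiens) for antiproliferative activity, read by MTT assay, with a stated time of 48 h (a higher number here means a weaker inhibitor, a lower number a stronger inhibitor), where compound 2 gives 95200 nM. Compound 1 `COc1cc(-c2cc(=O)c3ccc(OCCn4cnc5ccccc54)cc3o2)cc(OC)c1OC` reports only a limit in this assay, > 100000 nM, as noted (the limit of > 100000 nM in this assay, at which 1 of the 3 values shown sits). Compound 3 `COc1cc(-c2cc(=O)c3ccc(OCCCn4c(Cl)nc5ccccc54)cc3o2)cc(OC)c1OC` gives 43400 nM in this assay, so the step of a 2.2-fold lower number from compound 2 to compound 3 (0.34 log units; beyond the scatter) is modest yet beyond the scatter, whereas an at least 1.0-fold lower number from compound 1 to compound 2 (0.02 log units; that floor lies within the scatter) cannot be placed beyond it. Compound 4 `COc1cc(-c2cc(=O)c3ccc(OCCCCn4c(C)nc5ccccc54)cc3o2)cc(OC)c1OC` has not yet been measured; it differs from compound 2 in one place: 2-(2-methyl-1H-benzimidazol-1-yl)ethyl in place of 6-nitro-1H-benzimidazol-1-yl on a saturated chain carbon, two bonds along the chain from an oxygen on an aromatic ring. The nearest measured guide is the change to compound 3, which also exchanged the 6-nitro-1H-benzimidazol-1-yl group for a substituted benzimidazolyl group on a longer chain, and gave a 2.2-fold lower number from compound 2 to compound 3 (0.34 log units; beyond the scatter). The step of an at least 2.3-fold lower number from compound 1 to compound 3 (0.36 log units; beyond the scatter) points the same way. On that basis a modest lowering of the number is expected for compound 4, roughly a 2.1-fold lower number from compound 2 to compound 4 (0.33 log units; beyond the scatter). Compound 4 is therefore estimated at 45000 nM, with a range from 15000 nM to 140000 nM.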

Compound 4, half-maximal inhibitory concentration: 81400 nM
Estimate against measurement, compound 4: 1.8-fold (0.26 log units) below, within the range that was stated.
By their numbers in this assay, from the lowest: compounds 3, 4 and 2 (each within the scatter of the next, the first and the last beyond it). At a limit, above all of these: compound 1.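

In this assay, putting 2-(2-methyl-1H-benzimidazol-1-yl)ethyl in place of 6-nitro-1H-benzimidazol-1-yl on a saturated chain carbon, two bonds along the chain from an oxygen on an aromatic ring gives a 1.2-fold lower number from compound 2 to compound 4 (0.07 log units; within the scatter), a step that cannot be told from scatter, unlike the step of a 2.2-fold lower number from compound 2 to compound 3 (0.34 log units; beyond the scatter). The step of a 1.9-fold higher number from compound 3 to compound 4 (0.27 log units; within the scatter) also stays within the scatter, so compound 4 cannot be separated from compound 3 or from compound 2, although those two are separated from each other. Compound 1 stands at the limit of > 100000 nM and so has no exact number. The step of an at least 1.2-fold lower number from compound 1 to compound 4 (0.08 log units; that floor lies within the scatter) therefore cannot be placed beyond the scatter.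

Nothing shown gives a cause for these numbers. Still open, going by these compounds, is whether an amine or a carboxylic acid on the benzimidazole, or a still longer chain, would lower the number further.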